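The source may hold more compounds than are shown below. What is called first, only, known or untested is meant among the compounds shown, and "the series" means these compounds.

Compound 1 `CO[C@H](C)[C@H](N)CN(C(=O)[C@@H]1C[C@H]1c1ccccc1)c1ccc(-c2ccccc2)cc1`, compound 2 `CCC(CC)C(N)CCN(C(=O)[C@@H]1C[C@H]1c1ccccc1)c1ccc(-c2ccccc2)cc1` and compound 3 `CC[C@H](C)[C@H](N)CN(C(=O)[C@@H]1C[C@H]1c1ccc(F)cc1)c1ccc(-c2ccccc2)cc1` share a core and were tested in a functional assay for agonist activity at G protein-coupled receptor 88 (Homo sapiens), read by HTRF and cAMP accumulation; on this read-out lower numbers stand for an effect already at smaller amounts and higher numbers for an effect only at larger amounts of compound. Within the data shown here, compound 1 gives 0.68 nM, and compound 2 gives 2 nM; the one measured step, a 2.9-fold higher number from compound 1 to compound 2 (0.47 log units; beyond the scatter), concerns the chain on the amide-type nitrogen. Compound 3 gives 600 nM, the highest number of the three. Compound 4 `CC[C@H](C)[C@H](N)CN(C(=O)[C@@H]1C[C@H]1c1nccs1)c1ccc(-c2ccccc2)cc1` differs from compound 3 by 1,3-thiazol-2-yl in place of 4-fluorophenyl on a saturated ring carbon. Among the measured compounds shown here, no measured step touches this position, so nothing here bears directly on it, and the direction is open. Compound 4 is therefore expected to stay near compound 3, with a step of a 1.5-fold higher number from compound 3 to compound 4 (0.18 log units; within the scatter) that need not exceed the scatter, giving an estimate of 900 nM in this assay, within 150 nM to 5000 nM.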

Compound 4, half-maximal effective concentration: 210 nM
Compound 4: the middle estimate sits 4.3-fold (0.63 log units) above what was measured; low and high end bracket the measured number.
By their numbers in this assay, from the lowest: compound 1; then compound 2; then compound 4; then compound 3.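

In this assay, among these compounds, this is the first reading of the position on the saturated ring carbon of the three-membered ring: the change to 1,3-thiazol-2-yl from 4-fluorophenyl gives a 2.9-fold lower number from compound 3 to compound 4 (0.46 log units; beyond the scatter), a modest shift. The position therefore responds to the ring it carries, and a five-membered aromatic ring with 2 hetero atoms is accepted there. Nothing available accounts for this step.

Going by these compounds, whether a pyridin-2-yl or 1,3-oxazol-2-yl group would move the number further remains open. So does whether the step would carry over to the chain of compound 1.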